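The source may report more compounds than this note shows. Statements on the series, on what has been measured and on what is new or still open speak of the compounds shown alone.

Working notes on the aryl series. Three members are in hand: compound 1 `Cc1ccc(-c2cc(C)n(S(=O)(=O)Oc3ccccc3)n2)cc1`, compound 2 `Cc1cccc(-c2cc(C)n(S(=O)(=O)Oc3ccccc3)n2)c1` and compound 3 `Cc1cc(-c2cccc(Cl)c2)nn1S(=O)(=O)Oc1ccccc1`, all sharing the same core and differing only in the substituted phenyl group on one carbon of the five-membered ring. In a functional assay on the whole organism for inhibition, with Mus musculus as the target, with stated times of 3 days and 30 min, at a dose of 30 mg/kg by the oral route (on this read-out lower numbers stand for less inhibition and higher numbers for more inhibition at the one dose given (going by the name of the read-out)), compound 1 gives 15.2%, compound 2 gives 8.7% and compound 3 gives 10%. Compound 3 holds the second highest of the three numbers; its nearest neighbour is compound 2, with a number 1.3 percentage points higher from compound 2 to compound 3 (within the scatter), and its furthest is compound 1, with a number 5.2 percentage points lower from compound 1 to compound 3 (within the scatter). The remaining step, a number 6.5 percentage points lower from compound 1 to compound 2 (within the scatter), is likewise within the scatter, so the three numbers cannot be ordered.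

The next member is compound 4 `Cc1cc(-c2ccccn2)nn1S(=O)(=O)Oc1ccccc1`. Relative to compound 3 the change is pyridin-2-yl in place of 3-chlorophenyl on an aromatic carbon. All three measured steps bear on this position, since each swaps one substituted phenyl for another there, and none of them reached beyond the scatter. Within the data shown here, no measured step exchanges the carbon-only ring for a ring with a hetero atom, so the present change is not directly covered. Given that, the step expected in this assay is no change at the digits printed from compound 3 to compound 4 (within the scatter), with no direction beyond the scatter. The estimate for compound 4 is therefore 10%, with a range from 0% to 25%.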

Compound 4, a percentage reported as inhibition, in the whole organism at one dose (the size of the read-out at that dose, not a potency): 11.3%
Compound 4: middle estimate off by 1.3 percentage points, on the low side, and the stated range covers the measured number.
By their numbers in this assay, from the lowest: compounds 2, 3, 4 and 1 (each within the scatter of the next).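

Pyridin-2-yl is the first group at this position with a hetero atom in its ring and a hydrogen-bond acceptor, whereas the earlier steps only exchanged one substituted phenyl for another. In this assay the step reads a number 1.3 percentage points higher from compound 3 to compound 4 (within the scatter) against the 3-chlorophenyl member, a number 2.6 percentage points higher from compound 2 to compound 4 (within the scatter) against the 3-methylphenyl member and a number 3.9 percentage points lower from compound 1 to compound 4 (within the scatter) against the 4-methylphenyl member. Exchanging a carbon-only ring for this ring with a hetero atom therefore gives no separable step at this position, and the four compounds cannot be ordered on this read-out, while no measurement is at hand that would account for the numbers.

Still open, going by these compounds, is whether any group at this position gives a step beyond the scatter, for example pyridin-3-yl, an amine or a carboxylic acid on the phenyl ring, or a longer chain in place of the ring. Also open, on these data alone, is what the methyl group and the rest of the shared core contribute, since both stay the same in all four compounds.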